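The compounds below may be only part of what the source reports. "The series", "measured", "known", "first", "only" and "open" are said of these compounds alone.

Measured so far in a toxicity assay on Vero cells (Chlorocebus sabaeus) for cytotoxicity; a higher number here means that more compound is tolerated, a lower number that less compound is tolerated:
compound 1 `COc1nc(C(C)(C)C)ccc1[C@@H](c1ccccc1)[C@@](O)(CCN(C)C)c1cccc2ccccc12` — 27.6 ug/mL
compound 2 `COc1nc(-c2ccc(F)cc2)ccc1[C@@H](c1ccccc1)[C@@](O)(CCN(C)C)c1cccc2ccccc12` — > 50 ug/mL

Compound 2 stands at the edge of what this assay can report: its value of > 50 ug/mL is a limit, not a number, as the limit of > 50 ug/mL in this assay, at which 1 of the 2 values shown sits, records. Compound 3 `COc1nc(-c2ccccc2Cl)ccc1[C@@H](c1ccccc1)[C@@](O)(CCN(C)C)c1cccc2ccccc12` differs from compound 2 by 2-chlorophenyl in place of 4-fluorophenyl on an aromatic carbon. Within the data shown here, the only measured step, an at least 1.8-fold higher number from compound 1 to compound 2 (0.25 log units; that floor lies within the scatter), covers a different change, an aryl group replacing tert-butyl, and its floor lies within the scatter; no measured step exchanges one aryl group for another, so nothing here sizes an aryl-for-aryl swap. With compound 2 already at the limit, compound 3 is expected to sit there too, and the step of a number no higher from compound 2 to compound 3 (the limit leaves the size open) is expected to be none beyond the scatter. Compound 3 is therefore estimated at 50 ug/mL in this assay, within 25 ug/mL to 100 ug/mL, most likely reported again only as a limit.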

Compound 3, half-maximal cytotoxic concentration: > 50 ug/mL
Compound 3 ended at the assay's limit; the forecaster's own chance of this, stated with the estimate: 60%; the middle value lies on the limit itself.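

In this assay compound 3 gives > 50 ug/mL, which is a limit and not a number. A second aryl group at this position, 2-chlorophenyl in place of 4-fluorophenyl, therefore also reaches the end of the readable range, and the replacement of tert-butyl reads as an at least 1.8-fold higher number from compound 1 to compound 3 (0.25 log units; that floor lies within the scatter). The step between the two aryl compounds cannot be read, and the readable range now stops short for most of the compounds shown: the limit of > 50 ug/mL in this assay, at which 2 of the 3 values shown sit.

On these data alone, how far compound 2 and compound 3 lie past that limit stays open, and so does whether any aryl group at this position falls short of it. A morpholine or a carboxylic acid in this place on the shared core would test whether the tolerance in this assay needs an aromatic ring here at all.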